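The compounds below may be only part of what the source reports. "The series", "measured", "known", "first", "only" and "open" are said of these compounds alone.

Measured compounds:
- compound 1 `COc1cccc(-n2cc3nc(-c4cccnc4C)n(C[C@H]4CCCN(CC5CCO5)C4)c(=O)c3n2)c1`: 23 nM
- compound 2 `CCO[C@H](C)CN1CCC[C@H](Cn2c(-c3cccnc3C)nc3cn(-c4cccc(OC)c4)nc3c2=O)C1`: 40 nM
- compound 3 `COc1cccc(-n2cc3nc(-c4cccnc4C)n(C[C@H]4CCCN(CC5CCC5)C4)c(=O)c3n2)c1`: 1.6 nM

In an assay on HEK293 cells for displacement of a labelled ligand from growth hormone secretagogue receptor type 1 (Homo sapiens), with a stated time of 60 min (on this read-out lower numbers stand for stronger inhibition and higher numbers for weaker inhibition), compound 1 gives 23 nM. Its nearest neighbour is compound 2, separated by a 1.7-fold higher number from compound 1 to compound 2 (0.24 log units; within the scatter), while compound 3 is furthest away, a 14-fold lower number from compound 1 to compound 3 (1.16 log units; beyond the scatter). Compound 4 `COc1cccc(-n2cc3nc(-c4cccnc4C)n(C[C@H]4CCCN(CC5CCCCC5)C4)c(=O)c3n2)c1` is not yet measured; relative to compound 1 the change is cyclohexyl in place of oxetan-2-yl on a saturated chain carbon bound to an amine nitrogen in a ring. For the measured compounds named here, the steps that bear on it are those replacing the oxetan-2-yl or 1-ethoxyethyl with a carbocycle: a 14-fold lower number from compound 1 to compound 3 (1.16 log units; beyond the scatter) and a 25-fold lower number from compound 2 to compound 3 (1.40 log units; beyond the scatter), both large. A carbocycle at this position is therefore expected to bring a lower number in this assay for compound 4 as well, estimated as a 7.7-fold lower number from compound 1 to compound 4 (0.88 log units; beyond the scatter). Compound 4 is thus expected to give about 3 nM, in the range 1 nM to 12 nM.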

Compound 4, half-maximal inhibitory concentration: 200 nM
Compound 4: the middle estimate sits 67-fold (1.82 log units) below what was measured, outside the stated range (above it).
By their numbers in this assay, from the lowest: compound 3; then compounds 1 and 2 (each within the scatter of the next); then compound 4.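

In this assay, a carbocycle on a saturated chain carbon bound to an amine nitrogen in a ring does not by itself bring a lower number: enlarging cyclobutyl to cyclohexyl gives by far the largest step here (a 130-fold higher number from compound 3 to compound 4 (2.10 log units; beyond the scatter)). Cyclohexyl also falls behind both oxygen-bearing groups (an 8.7-fold higher number from compound 1 to compound 4 (0.94 log units; beyond the scatter); a 5.0-fold higher number from compound 2 to compound 4 (0.70 log units; beyond the scatter)). No measurement offered here accounts for this reversal.

A cyclopentyl group would show whether the number climbs gradually or abruptly between cyclobutyl and cyclohexyl. Going by these compounds, whether an amine on the cyclohexyl ring would change the outcome also remains open.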